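Adding a Second Fluorine to the Methoxyphenyl Ring

The compounds below may be only part of what the source reports. "The series", "measured", "known", "first", "only" and "open" are said of these compounds alone.

Compound 2 `COc1c(F)cccc1C1CCN(c2ccn3c(CC4CC4)nnc3c2Cl)CC1` stands highest of the two measured compounds: in a functional assay on CHO cells for agonist activity at metabotropic glutamate receptor 2 (Homo sapiens), read by scintillation counting and GTPgammaS binding, with a stated time of 30 min (on this read-out lower numbers stand for smaller maximal responses and higher numbers for larger maximal responses), compound 2 gives 336%. Compound 1 `COc1cccc(F)c1C1CCN(c2ccn3c(CC4CC4)nnc3c2Cl)CC1` in this assay gives 304%. Among the compounds with values here, the only measured step is a number 32 percentage points higher from compound 1 to compound 2 (beyond the scatter). Compound 3 `COc1cc(F)cc(F)c1C1CCN(c2ccn3c(CC4CC4)nnc3c2Cl)CC1` differs from compound 2 by 2,4-difluoro-6-methoxyphenyl in place of 3-fluoro-2-methoxyphenyl on a saturated ring carbon. The step from compound 1 to compound 2 bears on this change only loosely, since 2,4-difluoro-6-methoxyphenyl resembles the 2-fluoro-6-methoxyphenyl of compound 1, whose value 304% was lower. Compound 3 is therefore expected to show a modest drop, a number 26 percentage points lower from compound 2 to compound 3 (beyond the scatter). Compound 3 is estimated at 310%, between 260% and 360%.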

Compound 3, largest response reached (Emax), in percent of the reference or control that the assay uses: 256%
Compound 3: the middle estimate sits 54 percentage points above what was measured, outside the stated range (below it).
By their numbers in this assay, from the lowest: compound 3; then compound 1; then compound 2.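

Fluoro in place of hydrogen on an aromatic carbon of the 2-fluoro-6-methoxyphenyl group gives [ a number 48 percentage points lower from compound 1 to compound 3 (beyond the scatter) ] in this assay, so this aryl group responds to an added fluorine as well as to where a single fluorine sits. Against the 3-fluoro-2-methoxyphenyl group, the 2,4-difluoro-6-methoxyphenyl group gives [ a number 80 percentage points lower from compound 2 to compound 3 (beyond the scatter) ], leaving compound 3 lowest of the three. Nothing available explains these drops. The compounds leave open whether chlorine or a methyl group in place of the added fluorine would lower the response too. They also leave open how a 2-ethoxy group in place of the methoxy would fare.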